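A few compounds are considered here, and "the series" means these few. Any claim that something is new, unique, unknown or untested is made for them only; others in the source may bear on it.

Measured so far in a functional assay on A549 cells (Homo sapiens) for cytotoxicity, read by MTT assay, with a stated time of 72 h; a lower number here means a stronger inhibitor, a higher number a weaker inhibitor:
- compound 1 `CNC(=O)c1cc(Oc2ccc(NC(=O)c3nn(-c4ccccc4C(F)(F)F)c(=O)cc3C)cc2F)ccn1`: > 40000 nM; this is a limit of the assay, not a number.
- compound 2 `CNC(=O)c1cc(Oc2ccc(NC(=O)c3nn(-c4cccc(F)c4)c(=O)cc3C)cc2F)ccn1`: 9540 nM.
- compound 3 `Cc1cc(=O)n(-c2ccc(Br)cc2F)nc1C(=O)Nc1ccc(Oc2ncnc3ccsc23)cc1`: 7930 nM.

Compound 3 gives the lowest of the two real numbers in this assay, with compound 2 nearest and within the scatter of it. Compound 1 sits at the limit of > 40000 nM in this assay, at which 1 of the 3 values shown sits, so its position relative to the others is known only as a limit.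

Compound 4 `Cc1cc(=O)n(-c2ccc(F)c(F)c2)nc1C(=O)Nc1ccc(Oc2ncnc3ccsc23)cc1` differs from compound 3 in one place: 3,4-difluorophenyl in place of 4-bromo-2-fluorophenyl on an aromatic nitrogen. Among the compounds with values here, the only measured step that also swaps the aryl group on that aromatic nitrogen is an at least 4.1-fold lower number from compound 1 to compound 2 (0.62 log units; beyond the scatter), which removed the 2-(trifluoromethyl)phenyl group and was at least modest. Within the data shown here, the present change keeps a halogenated phenyl at the same position and exchanges one pair of halogen substituents for another; the earlier step gives no direct precedent for this particular pair. A step within the scatter is therefore expected, in either direction. Compound 4 is estimated at 6500 nM, with a range of 2500 nM to 20000 nM, meaning an expected step of a 1.2-fold lower number from compound 3 to compound 4 (0.09 log units; within the scatter).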

Compound 4, half-maximal inhibitory concentration: 8180 nM
Compound 4: the middle estimate sits 1.3-fold (0.10 log units) below what was measured; the range from low to high includes it.
By their numbers in this assay, from the lowest: compounds 3, 4 and 2 (each within the scatter of the next). At a limit, above all of these: compound 1.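

In this assay, 3,4-difluorophenyl in place of 4-bromo-2-fluorophenyl on the aromatic nitrogen gives a 1.0-fold higher number from compound 3 to compound 4 (0.01 log units; within the scatter), so on this core the number does not register the exchange of one halogenated phenyl group for the other. Within the data shown here, the only earlier exchange at this position, an at least 4.1-fold lower number from compound 1 to compound 2 (0.62 log units; beyond the scatter), lay beyond the scatter on a different core, and the new step shows that an aryl exchange here does not always move the number. No measurement shown bears on why this step stays within the scatter.

Still open, from the compounds shown here alone, is whether the number holds with an unsubstituted phenyl, or with a phenyl carrying an amine or a carboxylic acid, at this position. Also open, going by these compounds, is whether the two cores respond alike to one and the same aryl group.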